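The compounds below may be only part of what the source reports. "The series", "measured", "known", "first", "only" and "open" are said of these compounds alone.

Measured compounds:
Compound 1 `O=C([C@@H]1CCCN(S(=O)(=O)c2ccc(S(=O)(=O)N3CC[C@@H](O)C3)cc2)C1)N1CCC(F)(F)CC1` — 330 nM
Compound 2 `CCN(CC)S(=O)(=O)c1ccc(S(=O)(=O)N2CCC[C@@H](C(=O)N3CCOCC3)C2)cc1` — 790 nM
Compound 3 `CCN(CC)S(=O)(=O)c1ccc(S(=O)(=O)N2CCC[C@@H](C(=O)N[C@H]3CC[C@@H](OC)CC3)C2)cc1` — 2150 nM

Of the compounds shown here, three sharing one core have been tested in a functional assay on BXPC-3 cells (Homo sapiens) for inhibition, read by MTT assay, with a stated time of 7 days; a lower number here means a stronger inhibitor, a higher number a weaker inhibitor. Compound 2 stands second highest of the three numbers: compound 1 sits nearest to it, with a lower number, while compound 3 lies furthest, with a higher number.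

The unmeasured compound 4 `CCN(CC)S(=O)(=O)c1ccc(S(=O)(=O)N2CCC[C@@H](C(=O)N3CCC(F)(F)CC3)C2)cc1` is reached from compound 2 by a single change: 4,4-difluoropiperidin-1-yl in place of morpholin-4-yl on a carbonyl carbon.

Within the data shown here, only one measured step touches the same position. It runs a 2.7-fold higher number from compound 2 to compound 3 (0.43 log units; beyond the scatter) and shows that replacing the group on the carbonyl carbon can move the number beyond the scatter. The difluoropiperidine itself appears in compound 1, yet compound 1 differs from compound 2 in two places, so its value and that of compound 2 can only be set side by side. No direct measurement covers the exchange itself.

Given the lower number of compound 1, compound 4 is expected to show a modest decrease, a 1.6-fold lower number from compound 2 to compound 4 (0.20 log units; within the scatter). The estimate for compound 4 in this assay is 500 nM, with a range from 200 nM to 1300 nM.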

Compound 4, half-maximal inhibitory concentration: 120 nM
The estimate for compound 4 lay 4.2-fold (0.62 log units) above the measured number; measured number below the stated range.
By their numbers in this assay, from the lowest: compound 4; then compound 1; then compound 2; then compound 3.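

In this assay, the exchange of morpholin-4-yl for 4,4-difluoropiperidin-1-yl on the carbonyl carbon now has a direct reading (a 6.6-fold lower number from compound 2 to compound 4 (0.82 log units; beyond the scatter)), and it runs opposite to the earlier change to (4-methoxycyclohexyl)amino (a 2.7-fold higher number from compound 2 to compound 3 (0.43 log units; beyond the scatter)), so this position can move the number either way, and the two groups that entered compound 2's position stand far apart (an 18-fold lower number from compound 3 to compound 4 (1.25 log units; beyond the scatter)). Compound 4 also gives compound 1 a partner that differs in one place: with 4,4-difluoropiperidin-1-yl held on the carbonyl carbon, diethylamino in place of 3-hydroxypyrrolidin-1-yl on the sulfonyl sulfur also lowers the number (a 2.8-fold lower number from compound 1 to compound 4 (0.44 log units; beyond the scatter)), so that site matters as well. Nothing available here accounts for the size or direction of these steps.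

From the compounds shown here alone, it remains open whether plain piperidin-1-yl, without fluorine, or 4-fluoropiperidin-1-yl would sit nearer compound 4 or compound 2, which would separate the part played by the fluorines from that played by the ring carbon replacing the morpholine oxygen. Going by these compounds, it is also open whether the same exchange on the carbonyl carbon would give a step of similar size with 3-hydroxypyrrolidin-1-yl on the sulfonyl sulfur.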